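This account rests on a few compounds, and the source may have more. Where it says the series, first, only, none or still open, it means among the compounds named here.

Measured compounds in an assay on isolated protein for agonist activity at Bile acid receptor (Homo sapiens), read by FRET; on this read-out higher numbers stand for larger maximal responses and lower numbers for smaller maximal responses:
- Compound 1 `CN(Cc1cccc(C(=O)O)c1)c1ccc(OCc2c(-c3c(Cl)cccc3Cl)noc2C2CC2)nc1C(F)(F)F`: 102%
- Compound 2 `CC(Nc1ccc(C(=O)O)cc1)c1ccc(OCc2c(-c3c(Cl)cccc3Cl)noc2C2CC2)nc1C(F)(F)F`: 99%
- Compound 3 `CC(c1ccc(OCc2c(-c3c(Cl)cccc3Cl)noc2C2CC2)nc1C(F)(F)F)N(C)c1ccc(C(=O)O)cc1`: 102%

Compound 2 stands lowest of the three numbers, yet its separation from both neighbours is small: the step of a number 3 percentage points lower from compound 1 to compound 2 (within the scatter) and the step of a number 3 percentage points higher from compound 2 to compound 3 (within the scatter) each lie within the scatter, so the three compounds are not distinguishable on maximal response.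

Compound 4 `O=C(O)c1cccc(OCc2ccc(OCc3c(-c4c(Cl)cccc4Cl)noc3C3CC3)nc2C(F)(F)F)c1` has not yet been measured. Its change from compound 2 is (3-carboxyphenoxy)methyl in place of 1-((4-carboxyphenyl)amino)ethyl on an aromatic carbon. The step from compound 1 to compound 2 also exchanged the whole group at this same aromatic carbon, and it stayed within the scatter; the step from compound 2 to compound 3 touched the same group and stayed within the scatter too. Nothing seen so far therefore points to a shift beyond the scatter, and compound 4 is expected to show a step of a number 1 percentage points higher from compound 2 to compound 4 (within the scatter). Compound 4 is estimated at 100%, with a range from 86% to 112%.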

Compound 4, largest response reached (reported as efficacy), in percent of the reference or control that the assay uses: 98%
For compound 4 the middle estimate is 2 percentage points above the measured one; measured number inside the range.
By their numbers in this assay, from the lowest: compounds 4, 2, 1 and 3 (each within the scatter of the next).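

In this assay, the group at this aromatic carbon could lose its nitrogen, with (3-carboxyphenoxy)methyl entering, and the read-out still showed no separation: a number 1 percentage points lower from compound 2 to compound 4 (within the scatter) and a number 4 percentage points lower from compound 1 to compound 4 (within the scatter). The entering group also has one hydrogen-bond donor in place of the two in 1-((4-carboxyphenyl)amino)ethyl, so neither that nitrogen nor the second donor is needed to keep the maximal response within the scatter. Nothing available here explains this unchanged response.

Going by these compounds, all four compounds carry a carboxylic acid on this group, so the effect of an amide or a tetrazole in its place remains open.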